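Dimethoxybenzamide change on the weak end of the series

A few compounds are considered here, and "the series" means these few. Any claim that something is new, unique, unknown or untested is made for them only; others in the source may bear on it.

Values measured in a functional assay on MDA-MB-231 cells (Homo sapiens), read by microscopy and transwell migration, with a stated time of 24 h (on this read-out higher numbers stand for weaker inhibition and lower numbers for stronger inhibition), so far
compound 1 `CCCn1c(-c2ccc(C)cc2C)cs/c1=N\C(=O)c1ccccc1` gives 292 nM as a number
compound 2 `COc1cc(-c2csc(NC(=O)c3ccccc3)n2)cc(OC)c1OC` gives > 50000 nM as a limit of the assay

Compound 2 stands at the limit of > 50000 nM in this assay, at which 1 of the 2 values shown sits, and so offers only a limit, not a number. Compound 3 `COc1cc(-c2csc(NC(=O)c3cccc(OC)c3OC)n2)cc(OC)c1OC` differs from compound 2 by a single change 2,3-dimethoxyphenyl in place of phenyl on a carbonyl carbon in which 2,3-dimethoxyphenyl stands in place of phenyl on a carbonyl carbon. Within the data shown here, no measured step isolates this change, so the forecast stays loose. A modest move toward stronger inhibition in this assay is expected, and compound 3 may well return a limit too. The expected size of the move is an at least 2.0-fold lower number from compound 2 to compound 3 (0.30 log units; that floor lies within the scatter) and no larger. For compound 3 the estimated value is 25000 nM with an expected range from 5000 nM to 50000 nM in these notes.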

Compound 3, half-maximal inhibitory concentration: 15000 nM
Compound 3: the middle estimate sits 1.7-fold (0.22 log units) above what was measured, and the stated range covers the measured number.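

On a carbonyl carbon whose other neighbour is an amide-type nitrogen, 2,3-dimethoxyphenyl in place of phenyl gives, in this assay, an at least 3.3-fold lower number from compound 2 to compound 3 (0.52 log units; beyond the scatter). Compound 2 gives a limit and not a number, so the size of this step is only a floor: the limit of > 50000 nM in this assay, at which 1 of the 3 values shown sits. Among these compounds, the change is the first in these notes to show that this position can affect the read-out. Compound 3 gives a measured number, 15000 nM.

The compounds shown do not separate the contributions of the two methoxy groups within 2,3-dimethoxyphenyl. They also leave open how this assay would respond to an amine or a carboxylic acid on that phenyl, and how this change would read on the core of compound 1.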